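A few compounds are considered here, and "the series" means these few. Any claim that something is new, unique, unknown or untested is made for them only; others in the source may bear on it.

Of the compounds shown here, three built on one shared core have so far been measured in a functional assay on RT-112 cells (Homo sapiens) for antiproliferative activity, read by MTT assay, with a stated time of 72 h (on this read-out lower numbers stand for stronger inhibition of growth and higher numbers for weaker inhibition of growth), and differ only in the aryl group on the amide-type nitrogen. Compound 1 (`COc1cc(Nc2ncnc3c(NC(=O)Nc4ccc(Cl)cc4)cccc23)cc(OC)c1`) gives 2490 nM and compound 2 (`COc1cc(Nc2ncnc3c(NC(=O)Nc4ccc(Cl)cc4Cl)cccc23)cc(OC)c1`) gives 3060 nM in the same test, with a 1.2-fold higher number from compound 1 to compound 2 (0.09 log units; within the scatter) between them. Compound 3 (`COc1cc(Nc2ncnc3c(NC(=O)Nc4cccc(C(F)(F)F)c4F)cccc23)cc(OC)c1`) gives 471 nM as the lowest number of the three, with a 5.3-fold lower number from compound 1 to compound 3 (0.72 log units; beyond the scatter) and a 6.5-fold lower number from compound 2 to compound 3 (0.81 log units; beyond the scatter) marking its lead. Compound 4 (`COc1cc(Nc2ncnc3c(NC(=O)c4cc(=O)c5ccccc5o4)cccc23)cc(OC)c1`) has not yet been measured and differs from compound 3 by a group of 11 heavy atoms (9 carbon, 2 oxygen; one six-membered aromatic ring of carbon only, one six-membered aromatic ring with 1 hetero atom) in place of a group of 12 heavy atoms (7 carbon, 1 nitrogen, 4 fluorine; one six-membered aromatic ring of carbon only), on a carbonyl carbon at that carbonyl carbon. Among the measured compounds shown here, no measured step makes a change of this kind, so the evidence is indirect. The 2-fluoro-3-(trifluoromethyl)phenyl group seen in a 5.3-fold lower number from compound 1 to compound 3 (0.72 log units; beyond the scatter) leaves in this change, and nothing shows that the lower number of compound 3 would survive its loss. The nearest guide is then compound 1 at 2490 nM as a typical number for this small set. A modest rise is therefore expected in this assay, with a 4.2-fold higher number from compound 3 to compound 4 (0.63 log units; beyond the scatter) as the estimated step, although its size is poorly constrained. Expected for compound 4 is 2000 nM within an estimated range from 500 nM to 8000 nM on the same read-out.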

Compound 4, concentration for 50% growth inhibition: > 20000 nM
Compound 4: no number, only a limit (the forecaster's own chance of this, stated with the estimate: 12%); middle value at least 10-fold (1.00 log units) from the limit.
By their numbers in this assay, from the lowest: compound 3; then compounds 1 and 2 (each within the scatter of the next). At a limit, above all of these: compound 4.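

In this assay, among the compounds shown here, compound 4 is held only at a limit of the assay, not at a number: the limit of > 20000 nM in this assay, at which 1 of the 4 values shown sits. The earlier compounds varied only the aryl group on the amide-type nitrogen and all gave measurable numbers, whereas here the (2-fluoro-3-(trifluoromethyl)phenyl)amino group leaves the carbonyl carbon altogether and a group with one six-membered aromatic ring of carbon only and one six-membered aromatic ring with 1 hetero atom enters. The change brings an at least 42-fold higher number from compound 3 to compound 4 (1.62 log units; beyond the scatter), and it also stands clear of the two weaker measured compounds, with an at least 6.5-fold higher number from compound 2 to compound 4 (0.81 log units; beyond the scatter) and an at least 8.0-fold higher number from compound 1 to compound 4 (0.90 log units; beyond the scatter), so at this carbonyl carbon the replacement loses more than any change among the aryl groups shown.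

This one step removes the amino nitrogen and its hydrogen-bond donor and brings in the new ring group all at once, so the compounds shown cannot say which of these parts accounts for the loss. Going by these compounds, whether a plain phenyl group or a morpholine on the same carbonyl carbon would keep a measurable number also stays open.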